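The compounds below may be only part of what the source reports. "The series", "measured", "known", "first", "only" and "open" are said of these compounds alone.

Compound 1 `C[C@@H](Cn1ccc(-c2ccc(C#N)c(Cl)c2)n1)NC(=O)c1ccccc1`: "not determined" (no result reported)
Compound 2 `C[C@@H](Cn1ccc(-c2ccc(C#N)c(Cl)c2)n1)NC(=O)c1cccc(OCC(O)CO)c1`: 590 nM
Compound 3 `CC(Cn1ccc(-c2ccc(C#N)c(Cl)c2)n1)C(=O)Nc1cc[nH]n1`: > 30000 nM, a limit of the assay

In a functional assay on VCaP cells (Homo sapiens) for antiproliferative activity, read by CCK-8 assay, with a stated time of 6 days (on this read-out lower numbers stand for stronger inhibition and higher numbers for weaker inhibition), compound 1 has no number of its own, its result reading "not determined" (no result reported). Compound 4 `C[C@@H](Cn1ccc(-c2ccc(C#N)c(Cl)c2)n1)Nc1cccnc1` remains unmeasured. The change is pyridin-3-yl in place of benzoyl on an amine nitrogen, with pyridin-3-yl in place of benzoyl on an amine nitrogen. With no value for compound 1, the step can only be expected in general terms: a move towards weaker inhibition, beyond the usual scatter. The nearest firm reference is compound 2 at 590 nM, and compound 4 is expected to fall on the weaker side of it. Compound 4 is estimated at 4000 nM in this assay, with an expected range of 700 nM to 25000 nM.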

Compound 4, half-maximal inhibitory concentration: > 30000 nM
Compound 4: only a limit was reported; the forecaster's own chance of this, stated with the estimate: 25%; middle value at least 7.5-fold (0.87 log units) from the limit.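

No step can be read between compound 1 and compound 4: compound 1 has no number, and compound 4 has only a limit of the assay. The compounds shown leave open whether benzoyl or pyridin-3-yl on the amine nitrogen gives stronger inhibition in this assay.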